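Sulfur to selenium exchange on the isoxazole series

This account rests on a few compounds, and the source may have more. Where it says the series, first, only, none or still open, it means among the compounds named here.

Compound 1 `CS/C(=N\C(=O)c1ccno1)NC(=O)c1ccno1` in a functional assay on HepG2 cells (Homo sapiens) for cytotoxicity, read by MTT assay, with a stated time of 72 h (on this read-out lower numbers stand for stronger inhibition of growth and higher numbers for weaker inhibition of growth), gives only a limit, > 100000 nM, and no number. It thus sits at the limit of > 100000 nM in this assay, at which 1 of the 3 values shown sits. Two further members of the wider set carry other aryl amides on the shared core: compound 2 `CS/C(=N\C(=O)c1cc2ccccc2s1)NC(=O)c1cc2ccccc2s1` gives 15800 nM in this assay, and compound 3 `O=C(/N=C(/NC(=O)c1cccs1)[Se]Cc1ccccc1)c1cccs1`, which already bears selenium in place of sulfur together with a benzyl group, gives 34700 nM. No step between measured compounds that differ in a single place is available, so the size of the sulfur-to-selenium exchange alone cannot be read from the numbers shown.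

Compound 4 `C[Se]/C(=N\C(=O)c1ccno1)NC(=O)c1ccno1` is not yet measured. It differs from compound 1 by a group of 2 heavy atoms (1 carbon, 1 selenium; no ring) in place of a group of 2 heavy atoms (1 carbon, 1 sulfur; no ring), on a carbon with a double bond to nitrogen; in words, a group of 2 heavy atoms (1 carbon, 1 selenium; no ring) in place of a group of 2 heavy atoms (1 carbon, 1 sulfur; no ring), on a carbon with a double bond to nitrogen. No step beyond the usual scatter is expected in this assay from such a small exchange on a compound that itself reached only a limit. Compound 4 is expected to give about 100000 nM, with a range from 40000 nM to 300000 nM, and the step from compound 1 to compound 4 is estimated at a number no higher from compound 1 to compound 4 (the limit leaves the size open); a limit again is the more likely outcome.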

Compound 4, concentration for 50% growth inhibition: 510 nM
Beside the measured number, compound 4's estimate is 200-fold (2.29 log units) above it, outside the stated range (below it).
By their numbers in this assay, from the lowest: compound 4; then compound 2; then compound 3. At a limit, above all of these: compound 1.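

The exchange of methylsulfanyl for its selenium counterpart, on a carbon with a double bond to nitrogen whose other neighbours are amide-type nitrogen, amide-type nitrogen, is the only single-place change shown in this series. In this assay it gives an at least 190-fold lower number from compound 1 to compound 4 (2.29 log units; beyond the scatter), so the identity of this one atom can decide whether the shared core with these amides inhibits growth at a measurable level. The true size of the step stays open on one side, as the value of compound 1 is a limit and not a number: the limit of > 100000 nM in this assay, at which 1 of the 4 values shown sits.

The compounds shown leave open whether the same exchange gives a step of similar size with the other aryl amides of compound 2 and compound 3. They also leave open how the selenium series responds when an ethyl chain or a chain ending in a carboxylic acid replaces the methyl group of compound 4.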